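Methyl for Chloro Next to the Ring Nitrogen

A few compounds are considered here, and "the series" means these few. Any claim that something is new, unique, unknown or untested is made for them only; others in the source may bear on it.

Compound 1, `COc1ccc(C2=NN(C(=O)c3ccc(Cl)nc3)C(c3ccc(OCc4ccccc4)cc3)C2)cc1`, gives 10600 nM in a functional assay on WM 266-4 cells (Homo sapiens) for antiproliferative activity, read by MTT assay, with a stated time of 24 h; a lower number here means a stronger inhibitor of growth, a higher number a weaker inhibitor of growth.
Compound 2, `O=C(c1ccc(Cl)nc1)N1N=C(c2ccc(Cl)cc2)CC1c1ccc(OCc2ccccc2)cc1`, gives 13200 nM.

Compound 2 carries the higher of the two numbers, but its gap to compound 1 lies within the scatter. Compound 3, `Cc1ccc(C(=O)N2N=C(c3ccc(Cl)cc3)CC2c2ccc(OCc3ccccc3)cc2)cn1`, differs from compound 2 by methyl in place of chloro on an aromatic carbon. Going by the values given here, the only measured step, a 1.2-fold higher number from compound 1 to compound 2 (0.10 log units; within the scatter), concerns a different ring and stayed within the scatter. Nothing measured touches the position next to the ring nitrogen, so the step expected in this assay is a 1.0-fold lower number from compound 2 to compound 3 (0.01 log units; within the scatter), none beyond the scatter. Compound 3 is therefore estimated at 13000 nM, with a range from 6000 nM to 30000 nM.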

Compound 3, concentration for 50% growth inhibition: 9200 nM
Compound 3: the middle estimate sits 1.4-fold (0.15 log units) above what was measured, within the range that was stated.
By their numbers in this assay, from the lowest: compounds 3, 1 and 2 (each within the scatter of the next).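

Methyl in place of chloro next to the ring nitrogen gives a 1.4-fold lower number from compound 2 to compound 3 (0.16 log units; within the scatter) in this assay and so stays within the scatter. Going by these compounds alone, the earlier step changed only the other aromatic ring, so this is the first reading at this position, and here one single heavy atom replacing another leaves the number without a clear change. Nothing measured on these compounds offers an explanation for this result.

On these data alone, whether an amine or a carboxylic acid at this position would move the number beyond the scatter remains open. Also open, as far as these compounds go, is whether the same swap would give a similar step with methoxy in place of chloro on the other ring.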